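Phenoxy for phenyl: working notes on compound 4

The compounds below may be only part of what the source reports. "The series", "measured", "known", "first", "only" and "open" are said of these compounds alone.

- compound 1 `COc1ccc(Cn2nnc(O)c2C(=O)Nc2cc(C(F)(F)F)cc(C(F)(F)F)c2)cc1`: 6910 nM
- compound 2 `COc1ccc(Cn2nnc(O)c2C(=O)Nc2ccc(-c3ccccc3)cc2)cc1`: < 1000 nM
- compound 3 `COc1ccc(Cn2nnc(O)c2C(=O)Nc2cccc(-c3ccc(O)cc3)c2)cc1`: 2050 nM

All three results come from a physicochemical assay for solubility, read by HPLC, in phosphate buffer, with a stated time of 24 h, at pH 7.4; a lower number here means a less soluble compound, a higher number a more soluble compound. Compound 1 gives the number 6910 nM and compound 3 gives the number 2050 nM.

Compound 2 reads < 1000 nM, which is a limit of the assay and not a number. Its place in the series is therefore known only as the limit of < 1000 nM in this assay, at which 1 of the 3 values shown sits.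

The next compound to be measured is compound 4 `COc1ccc(Cn2nnc(O)c2C(=O)Nc2ccc(Oc3ccccc3)cc2)cc1`. It differs from compound 2 by phenoxy in place of phenyl on an aromatic carbon, para to a large group (phenoxy in place of phenyl on an aromatic carbon). Within the data shown here, no two measured compounds differ in one place only, so the series offers no measured step to size this change against.

The expectation rests on compound 2 at < 1000 nM, a limit, and on the small count of the structural change. The expected size is a step that the limit leaves unreadable from compound 2 to compound 4, estimated as no shift in either direction beyond the scatter. Another result reported only as a limit is also expected to be more likely than not. In this assay the estimated value for compound 4 is 800 nM, with an expected range of 300 nM to 2000 nM.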

Compound 4, solubility: < 1000 nM
Compound 4 was reported as a limit; the forecaster's own chance of this, stated with the estimate: 60%; the middle value lies beyond the limit too.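

Compound 2 and compound 4 both read as limits and not as numbers, so no step can be read between them: the limit of < 1000 nM in this assay, at which 2 of the 4 values shown sit. The compounds shown leave open whether phenoxy in place of phenyl on an aromatic carbon shifts solubility at all, and if so, in which direction and by how much.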